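The source may hold more compounds than are shown below. What is called first, only, known or untested is meant among the compounds shown, and "the series" means these compounds.

Compound 1 `COCOc1cc(/C=C/C(=O)OCC(=O)Nc2ccc(OC)cc2)ccc1OCc1ccccc1` in a functional assay on LS174T cells (Homo sapiens) for cytotoxicity, read by MTT assay, with a stated time of 72 h (a higher number here means a weaker inhibitor, a lower number a stronger inhibitor), gives > 200000 nM, which is a limit of the assay rather than a number. Compound 2 `COCOc1cc(/C=C/C(=O)OCC(=O)Nc2ccc(Cl)cc2)ccc1OCc1ccccc1` in this assay gives > 200000 nM, also a limit. For the measured compounds named here, compound 3 `O=C(COC(=O)/C=C/c1ccc(O)c(O)c1)Nc1ccc(Cl)cc1` in this assay gives 108000 nM, the only number among the three.

From compound 2 to compound 1 the change is methoxy in place of chloro on an aromatic carbon, and its step that the two limits leave unreadable from compound 2 to compound 1 cannot be read since both values sit at the limit of > 200000 nM in this assay, at which 2 of the 3 values shown sit. Compound 4 `COc1ccc(NC(=O)COC(=O)/C=C/c2ccc(O)c(O)c2)cc1` is not yet measured; it stands to compound 3 as compound 1 stands to compound 2, through the same change, (methoxy in place of chloro on an aromatic carbon). How the core of compound 3 differs from that of compound 2 is not broken down here. Given that compound 3 gives 108000 nM while the earlier step is unreadable, the expected step for compound 4 in this assay is a 1.6-fold higher number from compound 3 to compound 4 (0.20 log units; within the scatter), a small one. Compound 4 is therefore estimated at 170000 nM, between 60000 nM and 450000 nM.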

Compound 4, half-maximal inhibitory concentration: 124000 nM
The estimate for compound 4 lay 1.4-fold (0.14 log units) above the measured number; the measured number falls inside the stated range.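

Where both compounds carry a real number, the change from 4-chlorophenyl to 4-methoxyphenyl gives a 1.1-fold higher number from compound 3 to compound 4 (0.06 log units; within the scatter) in this assay, so on this core the swap leaves no mark that stands out from ordinary assay noise. On the other core, the same change links compound 2 to compound 1, and that step cannot be read, since both compounds sit at a limit: the limit of > 200000 nM in this assay, at which 2 of the 4 values shown sit. The series therefore offers one readable step and nothing to compare it with, so it neither shows that the change carries from one core to another nor shows that it fails to.

Still open, going by these compounds, is what a different group would do in place of the chloro on the core of compound 3, such as an amine or a carboxylic acid. On these data alone, a longer chain in place of the methoxy on that core is equally open.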